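This account rests on a few compounds, and the source may have more. Where it says the series, first, only, none or still open, it means among the compounds named here.

Working notes on the series in a functional assay on the whole organism (artery, strain albino) with Rattus norvegicus as the target, with a stated time of 240 min, at a dose of 10 mg/kg by the oral route; on this read-out higher numbers stand for more inhibition at the one dose given (going by the name of the read-out) and lower numbers for less inhibition.

Compound 1 `CC1=C(C(=O)Nc2ccc(F)cc2)C(c2ccc([N+](=O)[O-])cc2)N=C(SCc2ccccc2)N1` gives 32.3% in this assay. Compound 2 `CC1=C(C(=O)Nc2ccc(F)cc2)C(c2ccc([N+](=O)[O-])cc2)N=C(SCc2ccc(Cl)cc2)N1`, which carries chloro in place of hydrogen on an aromatic carbon of the benzyl group, gives 33.3%; the step of a number 1 percentage points higher from compound 1 to compound 2 (within the scatter) stays within the scatter. Compound 3 `CC1=C(C(=O)Nc2ccc(Br)cc2)C(c2ccc(Cl)cc2Cl)N=C(SCc2ccccc2Cl)N1` gives 28.7%, the smallest of the three numbers, though its gaps to compound 1 and compound 2 are both within the scatter, so no ordering among the three can be claimed.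

Compound 4 `CC1=C(C(=O)Nc2ccc(Br)cc2)C(c2ccc(Cl)cc2Cl)N=C(SCc2ccc(Cl)cc2)N1` differs from compound 3 only in the benzyl-bound ring: 4-chlorophenyl in place of 2-chlorophenyl on a saturated chain carbon bound to a sulfur. For the measured compounds named here, no measured pair covers a move of the chlorine from one position of this ring to another. Going by the values given here, the only related step, a number 1 percentage points higher from compound 1 to compound 2 (within the scatter), concerns adding chloro to this same ring and was within the scatter. On that basis the step is expected to be a number 1.3 percentage points higher from compound 3 to compound 4 (within the scatter), not beyond the scatter. Compound 4 is therefore estimated to give 30% in this assay, expected between 18% and 42%.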

Compound 4, a percentage reported as inhibition, in the whole organism at one dose (the size of the read-out at that dose, not a potency): 32.3%
Estimate against measurement, compound 4: 2.3 percentage points below; measured number inside the range.
By their numbers in this assay, from the lowest: compounds 3, 1, 4 and 2 (each within the scatter of the next).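

In this assay the move from 2-chlorophenyl to 4-chlorophenyl on a saturated chain carbon bound to a sulfur gives a number 3.6 percentage points higher from compound 3 to compound 4 (within the scatter) and so stays within the scatter. For the compounds shown here, this is the first measured change in where the chlorine stands on this ring rather than whether it is present, and the earlier addition of chloro, a number 1 percentage points higher from compound 1 to compound 2 (within the scatter), also stays within the scatter on a different background. Neither change to this ring separates its pair of compounds, and no measurement available bears on why.

Still open, on these data alone, is whether a methoxy group or a carboxylic acid on this ring, or a longer chain in place of the benzyl group, would move the number beyond the scatter. The other positions also remain unresolved, as compound 1 and compound 3 differ in more than one place and cannot be compared.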